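Replacing the aryl group on the shared core

The compounds below may be only part of what the source reports. "The series", "measured", "known", "first", "only" and "open" are said of these compounds alone.

Measured compounds:
compound 1 `CCCCCCCCc1ccc(OCC(=O)Cn2nnnc2-c2cccc(S(=O)(=O)N(C)C)c2)cc1` — 1900 nM
compound 2 `CCCCCCCCc1ccc(OCC(=O)Cn2nnnc2-c2cccnc2)cc1` — 190 nM
compound 3 `CCCCCCCCc1ccc(OCC(=O)Cn2nnnc2-c2ccccn2)cc1` — 880 nM

In an assay on microsomes from brain for inhibition of Fatty-acid amide hydrolase 1 (Rattus norvegicus), read by fluorescence and HPLC, with a stated time of 60 min (on this read-out lower numbers stand for stronger inhibition and higher numbers for weaker inhibition), compound 3 holds the second highest of the three numbers: a 2.2-fold lower number from compound 1 to compound 3 (0.33 log units; beyond the scatter), and a 4.6-fold higher number from compound 2 to compound 3 (0.67 log units; beyond the scatter).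

Compound 4 `CCCCCCCCc1ccc(OCC(=O)Cn2nnnc2C(=O)OC)cc1` differs from compound 3 by methoxycarbonyl in place of pyridin-2-yl on an aromatic carbon. Going by the values given here, no measured step exchanges an aromatic group at this carbon for a group without a ring, so only indirect guidance exists: the swaps among aromatic groups at the same carbon, a 10-fold lower number from compound 1 to compound 2 (1.00 log units; beyond the scatter), a 2.2-fold lower number from compound 1 to compound 3 (0.33 log units; beyond the scatter) and a 4.6-fold higher number from compound 2 to compound 3 (0.67 log units; beyond the scatter), were all modest. A step of comparable size is therefore expected in this assay, its direction uncertain, with a higher number somewhat more likely than a lower one. For compound 4 the estimate is 1500 nM, range 400 nM to 6000 nM, which corresponds to an expected 1.7-fold higher number from compound 3 to compound 4 (0.23 log units; within the scatter).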

Compound 4, half-maximal inhibitory concentration: 1000 nM
For compound 4 the middle estimate is 1.5-fold (0.18 log units) above the measured one; the range from low to high includes it.
By their numbers in this assay, from the lowest: compound 2; then compounds 3, 4 and 1 (each within the scatter of the next, the first and the last beyond it).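

At this carbon, methoxycarbonyl, with no ring, reads level with pyridin-2-yl (a 1.1-fold higher number from compound 3 to compound 4 (0.06 log units; within the scatter)) and with 3-(dimethylsulfamoyl)phenyl (a 1.9-fold lower number from compound 1 to compound 4 (0.28 log units; within the scatter)), so an aromatic group is not needed to reach those numbers. Pyridin-3-yl alone stands apart from methoxycarbonyl (a 5.3-fold higher number from compound 2 to compound 4 (0.72 log units; beyond the scatter)), so the aromatic groups shown do not share a single advantage over it. No evidence on hand accounts for these steps.

As far as these compounds go, whether a carboxylic acid or an amide at this carbon reads like methoxycarbonyl remains open. So does whether any other ring matches compound 2.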